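The source may report more compounds than this note shows. Statements on the series, on what has been measured and on what is new or still open speak of the compounds shown alone.

Measured series:
- compound 1 `Cc1ccc(S(=O)(=O)NC(C2=CC(=O)c3c(O)ccc(O)c3C2=O)C(C)C)cc1`: "not determined" (no result reported) in a functional assay on HL-60 cells (Homo sapiens) for cytotoxicity, read by MTT assay; on this read-out higher numbers stand for weaker inhibition and lower numbers for stronger inhibition
- compound 2 `COc1ccc(S(=O)(=O)NC(C2=CC(=O)c3c(O)ccc(O)c3C2=O)C(C)C)c(OC)c1`: 400 nM in this assay
- compound 3 `CC(C)C(NS(=O)(=O)c1ccc(F)cc1)C1=CC(=O)c2c(O)ccc(O)c2C1=O`: "not determined" (no result reported) in this assay
- compound 4 `CC(C)C(NS(=O)(=O)c1cccc(Br)c1)C1=CC(=O)c2c(O)ccc(O)c2C1=O`: still to be measured in this assay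

All four share one core and differ only in the aryl group on the sulfonyl sulfur. Going by the values given here, compound 2 stands alone: its value in this assay is the only number the series has so far, and the two other measured entries give no figure to compare it with. Among the compounds with values here, no step between two measured compounds is therefore available, and nothing shows how the aryl group on the sulfonyl sulfur moves the read-out.

The change from compound 2 to compound 4 is 3-bromophenyl in place of 2,4-dimethoxyphenyl on a sulfonyl sulfur. Within the data shown here, with no measured step to lean on, the expectation for this assay is a step that stays near the scatter, in no particular direction, and the estimate is anchored on the value of compound 2 alone. Compound 4 is thus expected to fall near 500 nM, with a wide range from 150 nM to 2000 nM, which corresponds to an expected step of a 1.3-fold higher number from compound 2 to compound 4 (0.10 log units; within the scatter).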

Compound 4, half-maximal inhibitory concentration: 790 nM
For compound 4 the middle estimate is 1.6-fold (0.20 log units) below the measured one; low and high end bracket the measured number.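

In this assay the series now has its first readable step at the aryl group on the sulfonyl sulfur, a 2.0-fold higher number from compound 2 to compound 4 (0.30 log units; within the scatter). Replacing 2,4-dimethoxyphenyl, with its 2 hydrogen-bond acceptors, by 3-bromophenyl, with none, therefore does not separate the two compounds on this read-out, and a cytotoxic effect of this order persists with either aryl group. No measured property of either group bears on this result.

Compound 1 and compound 3 carry no number, so their steps to the other compounds cannot be read. As far as these compounds go, whether a different kind of substituent on the phenyl ring, such as an amine or a carboxylic acid, would move the read-out beyond the scatter remains open.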